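The source may report more compounds than this note shows. Statements on the series, on what has been measured and on what is new or still open speak of the compounds shown alone.

Measured so far in a functional assay on HepG2 cells (Homo sapiens) for antiproliferative activity, read by MTT assay, with a stated time of 48 h; a lower number here means a stronger inhibitor, a higher number a weaker inhibitor:
- compound 1 `COc1ccc(C(=O)c2ccc([N+](=O)[O-])cc2)cc1OC(=O)CCC(=O)OC[C@@H]1C=C[C@H](n2cc(C)c(=O)[nH]c2=O)O1`: 24000 nM
- compound 2 `COc1ccc(C(=O)c2ccc(F)cc2)cc1OCC(=O)OC[C@@H]1C=C[C@H](n2cc(C)c(=O)[nH]c2=O)O1`: 38000 nM

Both measured compounds share one core, and both give high numbers in this assay, meaning weak inhibition of cell growth. Compound 1 stands alongside compound 2: the two numbers lie within the usual scatter of each other, so the data do not separate them, and no ordering can be read from the pair. Among the compounds with values here, no step between measured compounds has been worked out here.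

Compound 3 `COc1cc(OC)c(C(=O)c2ccc(OC)c(OC(=O)CCC(=O)OC[C@@H]3C=C[C@H](n4cc(C)c(=O)[nH]c4=O)O3)c2)cc1OC` has not yet been measured. It differs from compound 1 in one place: 2,4,5-trimethoxyphenyl in place of 4-nitrophenyl on a carbonyl carbon. Within the data shown here, no measured pair shows what this kind of change does on this core, so the expectation rests only on the two numbers at hand, which are close to each other. The step of a 1.2-fold lower number from compound 1 to compound 3 (0.08 log units; within the scatter) is therefore expected to be small, with no clear direction beyond the scatter. Compound 3 is estimated to give 20000 nM in this assay, with a likely range from 7000 nM to 60000 nM.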

Compound 3, half-maximal inhibitory concentration: 6850 nM
Compound 3: middle estimate off by 2.9-fold (0.47 log units), on the high side, outside the stated range (below it).
By their numbers in this assay, from the lowest: compound 3; then compounds 1 and 2 (each within the scatter of the next).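

In this assay, putting 2,4,5-trimethoxyphenyl in place of 4-nitrophenyl on a carbonyl carbon gives a 3.5-fold lower number from compound 1 to compound 3 (0.54 log units; beyond the scatter). Within the data shown here, this is the first single-place step, and it shows that the aromatic group at this place can shift the reading beyond the scatter, which the close numbers of the first two compounds could not show. Nothing at hand accounts for the shift, and the whole 4-nitrophenyl group leaves while the whole 2,4,5-trimethoxyphenyl group enters in one step, so the data cannot say whether losing the first group or gaining the second matters more.

Still open, as far as these compounds go, is whether a plain phenyl ring, or a phenyl ring carrying a single methoxy group or an amine, would give a number closer to that of compound 1 or to that of compound 3. From the compounds shown here alone, it is also open whether the same exchange would produce a similar step on the core of compound 2, or on a version of the core of compound 1 with a longer chain.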